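The compounds below may be only part of what the source reports. "The series", "measured", "known", "first", "only" and "open" are said of these compounds alone.

Measured so far:
Compound 1 `c1cc(CN2CCN(CCCc3c[nH]c4ccc(-n5cnnc5)cc34)CC2)ccn1`: 0.6 nM
Compound 2 `CC(=O)Nc1ccc(CN2CCN(CCCc3c[nH]c4ccc(-n5cnnc5)cc34)CC2)cc1`: 2.5 nM

Going by the values given here, in an assay on CHO cells for displacement of a labelled ligand from 5-hydroxytryptamine receptor 1D (Homo sapiens) (a lower number here means a stronger inhibitor, a higher number a weaker inhibitor), compound 2 gives 2.5 nM, the highest number of the two; its nearest neighbour is compound 1 with 0.6 nM, and the only measured step is a 4.2-fold higher number from compound 1 to compound 2 (0.62 log units; beyond the scatter). Compound 3 `NC(=O)C(c1ccccc1)N1CCN(CCCc2c[nH]c3ccc(-n4cnnc4)cc23)CC1` differs from compound 2 by carbamoyl(phenyl)methyl in place of 4-acetamidobenzyl on an amine nitrogen in a ring. That step changes the group on the same ring nitrogen but exchanges different groups, so it bears only loosely here, and no step beyond the scatter is clearly indicated. Compound 3 is expected to give about 4 nM, within 1 nM to 15 nM. This estimate means a 1.6-fold higher number from compound 2 to compound 3 (0.20 log units; within the scatter).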

Compound 3, half-maximal inhibitory concentration: 0.2 nM
Compound 3: middle estimate off by 20-fold (1.30 log units), on the high side; measured number outside the range, below it.
By their numbers in this assay, from the lowest: compound 3; then compound 1; then compound 2.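

In this assay placing carbamoyl(phenyl)methyl on the ring nitrogen gives a 13-fold lower number from compound 2 to compound 3 (1.10 log units; beyond the scatter) and also a 3.0-fold lower number from compound 1 to compound 3 (0.48 log units; beyond the scatter) and so makes compound 3 the strongest of the three. The group leaving compound 2 and the group entering are close in heavy-atom count and share the same ring, donor and acceptor counts, so these counts alone do not set the number at this position. No measurement here explains the gain. The compounds shown leave open whether the carbamoyl group accounts for it, which a plain benzyl or a carboxylic acid in its place could test.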